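The compounds below may be only part of what the source reports. "The series", "measured", "known", "first", "only" and "open" are said of these compounds alone.

Working notes on the series. For the measured compounds named here, compound 1 `COc1cc(F)c(NC(=O)c2ncccn2)cc1Nc1nccc(-c2cn(C)c3ccccc23)n1` and compound 2 `COc1cc(N(C)CCN(C)C)c(NC(=O)c2cccnc2)cc1Nc1nccc(-c2cn(C)c3ccccc23)n1` share a core and differ at two places, so no single-change step between them can be stated; in a functional assay on NCI-H1975 cells (Homo sapiens) for antiproliferative activity, read by MTT assay, with a stated time of 72 h (on this read-out higher numbers stand for weaker inhibition and lower numbers for stronger inhibition), compound 1 gives 13500 nM, and in the same assay compound 2 gives 1750 nM. Compound 2 thus holds the lowest of the two numbers recorded, and the gap to compound 1 lies beyond the usual scatter.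

Compound 3 `COc1cc(N(C)CCN(C)C)c(NC(=O)c2ncccn2)cc1Nc1nccc(-c2cn(C)c3ccccc23)n1` is not yet measured. It keeps the whole of compound 2 except one change: pyrimidin-2-yl in place of pyridin-3-yl on a carbonyl carbon. Going by the values given here, no measured pair isolates this change, so its effect on the numbers is unknown. With compound 2 at 1750 nM as the only anchor, the step from compound 2 to compound 3 in this assay is expected to be a 1.1-fold higher number from compound 2 to compound 3 (0.06 log units; within the scatter), that is, not clearly beyond the scatter in either direction. Compound 3 is therefore estimated at 2000 nM, with a range from 700 nM to 6000 nM.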

Compound 3, half-maximal inhibitory concentration: 650 nM
Estimate against measurement, compound 3: 3.1-fold (0.49 log units) above, outside the stated range (below it).
By their numbers in this assay, from the lowest: compound 3; then compound 2; then compound 1.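

In this assay, for the compounds shown here, pyrimidin-2-yl in place of pyridin-3-yl on a carbonyl carbon gives a 2.7-fold lower number from compound 2 to compound 3 (0.43 log units; beyond the scatter) with the (2-(dimethylamino)ethyl)(methyl)amino group held constant, so this change, which no earlier pair isolated, now has a measured effect, a modest one. Going by these compounds alone, with pyrimidin-2-yl held constant on the carbonyl, (2-(dimethylamino)ethyl)(methyl)amino in place of fluoro on an aromatic carbon gives a 21-fold lower number from compound 1 to compound 3 (1.32 log units; beyond the scatter) and thus forms a large step, the first single-change reading at this aromatic carbon. No evidence is available that accounts for either step.

The compounds shown leave open how a phenyl ring or a pyridin-2-yl ring on the carbonyl carbon would compare with pyrimidin-2-yl. They also leave open whether a morpholine or a piperazine on the aromatic carbon would match the (2-(dimethylamino)ethyl)(methyl)amino group.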